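Bromo to Chloro: One Change Tested on Two Cores

This account rests on a few compounds, and the source may have more. Where it says the series, first, only, none or still open, it means among the compounds named here.

Compound 1 `NS(=O)(=O)c1ccc(C(=O)N/N=C(/CS(=O)(=O)c2ccccc2)c2ccc(Br)cc2)cc1` and compound 2 `NS(=O)(=O)c1ccc(C(=O)N/N=C(/CS(=O)(=O)c2ccccc2)c2ccc(Cl)cc2)cc1` share one core and differ in a single place: chloro in place of bromo on an aromatic carbon In a functional assay on MCF7 cells (Homo sapiens) for antiproliferative activity, read by MTT assay (a higher number here means a weaker inhibitor, a lower number a stronger inhibitor), compound 1 gives 19100 nM, while compound 2 gives 57000 nM; that is a 3.0-fold higher number from compound 1 to compound 2 (0.47 log units; beyond the scatter). Compound 3 `NS(=O)(=O)c1ccc(C(=O)N/N=C\c2ccc(Br)cc2)cc1` rests on a different core; how the two cores differ is not broken down here. In this assay compound 3 gives 1370 nM, the lowest of the three numbers. Compound 4 `NS(=O)(=O)c1ccc(C(=O)N/N=C\c2ccc(Cl)cc2)cc1` has not yet been measured and stands to compound 3 as compound 2 stands to compound 1: chloro in place of bromo on an aromatic carbon The place is the same in both pairs, so this is the same change already seen once. For compound 4 a step of similar size is expected, a 2.6-fold higher number from compound 3 to compound 4 (0.41 log units; beyond the scatter), resting on a 3.0-fold higher number from compound 1 to compound 2 (0.47 log units; beyond the scatter), though a single precedent on another core is a thin basis and the step could well fall within the scatter. Compound 4 is therefore estimated at 3500 nM, with a likely range from 1400 nM to 9000 nM.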

Compound 4, half-maximal inhibitory concentration: 36700 nM
Beside the measured number, compound 4's estimate is 10-fold (1.02 log units) below it, and the stated range ends below it.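

Carried from one core to the other, the change from bromo to chloro raised the number both times in this assay, but the size of the step did not carry over: the same change on two cores in this assay, a 3.0-fold higher number (0.47 log units; beyond the scatter) from compound 1 to compound 2 and a 27-fold higher number (1.43 log units; beyond the scatter) from compound 3 to compound 4, 9.0-fold (0.95 log units) apart, beyond the scatter of two such steps. The new step is large (a 27-fold higher number from compound 3 to compound 4 (1.43 log units; beyond the scatter)) , so on this evidence the step seen on the core of compound 1 did not predict the size of the step on the core of compound 3. Within the data shown here, with only two pairs, this shows that the direction held twice and the size did not; it gives no rule for a third core and does not show what sets the size of the step.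

The compounds shown leave open which part of the difference between the two cores goes with the gap between the two steps. They also leave open how other groups in the same place on the ring, such as fluoro, methyl, methoxy or a plain hydrogen, would behave on each core.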